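Tolerability of Amide Analogues in a Monocytic Cell Line

The source may hold more compounds than are shown below. What is called first, only, known or untested is meant among the compounds shown, and "the series" means these compounds.

Compound 1 `COc1ccc(-c2cnc(NC(=O)CCc3ccccc3)n2C)cc1`, a limit: > 100000 nM
Compound 2 `Cn1cc(-c2ccccc2)nc1NC(=O)c1ccc(F)cc1`, a limit: > 50000 nM
Compound 3 `Cn1c(-c2ccc(C#N)cc2)cnc1NC(=O)c1ccc(F)cc1`, a limit: > 50000 nM

In a toxicity assay on THP-1 cells (Homo sapiens) for inhibition (a higher number here means that more compound is tolerated, a lower number that less compound is tolerated), compound 1 gives only a limit, not a number. Among the measured compounds shown here, the two further values are limits as well, so no compound stands above or below another on this assay. Compound 1 sits at the limit of > 100000 nM in this assay, at which 1 of the 3 values shown sits, while compounds 2 and 3 sit at the limit of > 50000 nM in this assay, at which 2 of the 3 values shown sit. Compound 4 `COc1ccc(-c2cnc(NC(=O)c3ccccc3C#N)n2C)cc1` differs from compound 1 by 2-cyanophenyl in place of phenethyl on a carbonyl carbon. Compound 4 is expected to give 100000 nM, within a range from 50000 nM to 200000 nM. The step of a number no higher from compound 1 to compound 4 (the limit leaves the size open) is expected to be nothing beyond the scatter, as only limits are known for compound 1.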

Compound 4, half-maximal cytotoxic concentration: > 100000 nM
Compound 4 gave a limit, no number; the forecaster's own chance of this, stated with the estimate: 80%; the middle value sits exactly at the limit.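

Compound 4 gives only a limit, > 100000 nM. Among the compounds shown here, compound 1 also gives only a limit, so no step between compound 1 and compound 4 can be read. The compounds shown leave open at what concentration any of them becomes cytotoxic.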